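The source may hold more compounds than are shown below. What is called first, only, known or untested is meant among the compounds shown, and "the series" means these compounds.

Measured so far: compound 1 `Fc1cccc(Nc2nc3nonc3nc2Nc2ccccc2F)c1` gives 190 nM in an assay on mitochondria from L6 cells (Rattus norvegicus) for activation, with a stated time of 90 min; on this read-out higher numbers stand for an effect only at larger amounts of compound and lower numbers for an effect already at smaller amounts; compound 2 `CCOc1cccc(Nc2nc3nonc3nc2Nc2ccccc2F)c1` gives 2200 nM in this assay.

Within the data shown here, compound 2 stands at the higher of the two numbers in this assay; its only neighbour is compound 1, and the single measured step is a 12-fold higher number from compound 1 to compound 2 (1.06 log units; beyond the scatter), a large shift for a change at one aromatic carbon.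

Compound 3 `Fc1ccccc1Nc1nc2nonc2nc1Nc1ccccn1` differs from compound 2 by pyridin-2-yl in place of 3-ethoxyphenyl on a nitrogen on an aromatic ring. Among the measured compounds shown here, no measured step covers pyridin-2-yl on this nitrogen. For the measured compounds named here, the one step that touches the group on this nitrogen, a 12-fold higher number from compound 1 to compound 2 (1.06 log units; beyond the scatter), shows that what sits here moves the number strongly, and that the smaller group carried the lower number. The expectation for compound 3 therefore leans toward a lower number than compound 2, estimated as a 4.4-fold lower number from compound 2 to compound 3 (0.64 log units; beyond the scatter), with wide uncertainty since the swap to a ring with a hetero atom has no measured parallel in the series. Compound 3 is estimated at 500 nM, range 90 nM to 3000 nM.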

Compound 3, half-maximal effective concentration: 9000 nM
Beside the measured number, compound 3's estimate is 18-fold (1.26 log units) below it; the whole stated range lies below it.
By their numbers in this assay, from the lowest: compound 1; then compound 2; then compound 3.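

Size alone does not order this position: in this assay, the smaller pyridin-2-yl in place of 3-ethoxyphenyl gives a 4.1-fold higher number from compound 2 to compound 3 (0.61 log units; beyond the scatter), so the trend suggested by the first two compounds does not extend to this group. Pyridin-2-yl in place of 3-fluorophenyl gives a 47-fold higher number from compound 1 to compound 3 (1.68 log units; beyond the scatter), and in both steps the ring with a hetero atom carries the higher number, although each step also removes a substituent from the ring. Nothing available bears on the reason for this rise.

The compounds shown do not separate the effect of the ring nitrogen from the loss of the fluoro or ethoxy group. An unsubstituted phenyl, a pyridin-3-yl or pyridin-4-yl ring, or a fluoro-substituted pyridine on this nitrogen would address that question.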